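Pyrrolidinyl Returns to the Thiocarbonyl Carbon

The compounds below may be only part of what the source reports. "The series", "measured", "known", "first", "only" and "open" are said of these compounds alone.

Compound 1 `O=c1cc(CSC(=S)N2CCCC2)oc2ccccc12`: 35800 nM
Compound 2 `O=c1c(Cl)c(CSC(=S)N2CCCCC2)oc2ccccc12`: 1000 nM
Compound 3 `CC(C)N(C(=S)SCc1oc2ccccc2c(=O)c1Cl)C(C)C`: > 40000 nM

All three have been measured in a functional assay on MCF7 cells (Homo sapiens) for antiproliferative activity, read by MTT assay, with a stated time of 72 h; a higher number here means a weaker inhibitor, a lower number a stronger inhibitor. Compound 3 stands at the weak end of what has been seen: its reading of > 40000 nM is a limit of the assay and not a number, the point described by the limit of > 40000 nM in this assay, at which 1 of the 3 values shown sits. Within the data shown here, the one step that has been measured runs into it: an at least 40-fold higher number from compound 2 to compound 3 (1.60 log units; beyond the scatter), so the exchange of the cyclic amine for the open-chain one costs a great deal of potency.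

Compound 4 `O=c1c(Cl)c(CSC(=S)N2CCCC2)oc2ccccc12` differs from compound 3 in a single place: pyrrolidin-1-yl in place of diisopropylamino on a thiocarbonyl carbon. This reverses the kind of change that made compound 3 so weak, since a cyclic amine again sits on the thiocarbonyl carbon, now a five-membered ring rather than the six-membered one of compound 2. Among the measured compounds shown here, the step from compound 2 to compound 3 is the only measured guide, and it is large; the change from compound 3 to compound 4 is therefore expected to give a large fall in the number, bringing compound 4 back toward compound 2 while the limit on compound 3 leaves the exact size uncertain. Compound 1, the pyrrolidinyl analogue lacking the chlorine, gives 35800 nM, which marks the other end of where compound 4 might land.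

Compound 4 is estimated at 3000 nM, between 800 nM and 20000 nM. That expectation corresponds to a step of an at least 13-fold lower number from compound 3 to compound 4 (1.12 log units; beyond the scatter).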

Compound 4, half-maximal inhibitory concentration: 2300 nM
For compound 4 the middle estimate is 1.3-fold (0.12 log units) above the measured one; the range from low to high includes it.
By their numbers in this assay, from the lowest: compound 2; then compound 4; then compound 1. At a limit, above all of these: compound 3.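

In this assay, pyrrolidin-1-yl on the thiocarbonyl carbon recovers what diisopropylamino gave up, with an at least 17-fold lower number from compound 3 to compound 4 (1.24 log units; beyond the scatter), and the size of that step is only a bound, since it starts from a limit of the assay and not a number: the limit of > 40000 nM in this assay, at which 1 of the 4 values shown sits.

The two cyclic amines come close without matching, with a 2.3-fold higher number from compound 2 to compound 4 (0.36 log units; beyond the scatter), a modest step that still lies beyond the scatter, so good potency at this place does not belong to piperidin-1-yl alone, while the open-chain diisopropylamino remains the one group shown that goes against it. The earlier compounds shown here also offered no clean reading of the chloro group, and here, with pyrrolidin-1-yl held fixed, chloro in place of hydrogen on an aromatic carbon proves to be a large change, with a 16-fold lower number from compound 1 to compound 4 (1.19 log units; beyond the scatter).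

As far as these compounds go, what the same chloro exchange does with piperidin-1-yl on the thiocarbonyl carbon stays open, as does whether bromo or methyl could stand in for the chloro group. From the compounds shown here alone, it is also open whether a larger ring such as azepan-1-yl, a morpholin-4-yl ring or a smaller open-chain amine such as dimethylamino would hold the potency of the cyclic amines seen so far.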